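Piperidine in place of anisidine on a pyridine amide

The source may report more compounds than this note shows. Statements on the series, on what has been measured and on what is new or still open speak of the compounds shown alone.

Three compounds have been measured in an in vitro assay on HEK-tsA201 cells for antagonist activity at Neuronal acetylcholine receptor; alpha4/beta2 (Homo sapiens), read by fluorescence and calcium flux; a lower number here means a stronger inhibitor, a higher number a weaker inhibitor:
- compound 1, `CCCOc1ccc(C(=O)Nc2cccc(Nc3ccccc3F)n2)cc1`, reaches only the limit of this assay, > 100000 nM
- compound 2, `CCCOc1ccc(C(=O)Nc2cccc(Nc3cccc(F)c3)n2)cc1`, reaches only the limit, > 100000 nM
- compound 3, `CCCOc1ccc(C(=O)Nc2cccc(Nc3ccc(OC)cc3)n2)cc1`, likewise reaches only the limit, > 100000 nM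

For the measured compounds named here, compound 3 thus stands where every value so far sits, at the limit of > 100000 nM in this assay, at which 3 of the 3 values shown sit. All three readings are limits rather than numbers. The steps between them, a step that the two limits leave unreadable from compound 1 to compound 2, a step that the two limits leave unreadable from compound 1 to compound 3 and a step that the two limits leave unreadable from compound 2 to compound 3, cannot be read, and nothing is known about how the aryl group on the ring nitrogen-bound amine affects inhibition.

Compound 4, `CCCOc1ccc(C(=O)Nc2cccc(N3CCCCC3)n2)cc1`, is not yet measured. It differs from compound 3 by piperidin-1-yl in place of (4-methoxyphenyl)amino on an aromatic carbon. The amine hydrogen and the aromatic substituent both go; a saturated ring takes their place, on an aromatic carbon next to the ring nitrogen and meta to a large group.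

Going by the values given here, no measured step bears on this change in a readable way, so the expectation rests only on the three limits. Compound 4 is therefore expected to remain at or near the limit, with an estimated value of 100000 nM, ranging from 20000 nM to 500000 nM. The expected step is a number no higher from compound 3 to compound 4 (the limit leaves the size open), which is most likely no readable change at all.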

Compound 4, half-maximal inhibitory concentration: > 100000 nM
Compound 4: only a limit was reported; the forecaster's own chance of this, stated with the estimate: 85%; the middle value sits exactly at the limit.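

In this assay compound 4 gives > 100000 nM, which is a limit of the assay and not a number. Its steps from compound 1, compound 2 and compound 3 therefore cannot be read: the limit of > 100000 nM in this assay, at which 4 of the 4 values shown sit.

Still open, on these data alone, is how strongly any of these four compounds inhibits, and whether piperidin-1-yl or (4-methoxyphenyl)amino gives the stronger inhibitor.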